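Chloro in Place of Methyl on the Benzyl Arm

The source may hold more compounds than are shown below. What is called first, only, known or untested is meant among the compounds shown, and "the series" means these compounds.

Among the measured compounds shown here, compound 1 `Cc1ccc(CN2c3ccccc3C(=O)N(Cc3ccccc3)S2(=O)=O)cc1` is the one compound with a plain number in a functional assay on MRC5 cells (Homo sapiens); on this read-out lower numbers stand for higher toxicity in this test and higher numbers for lower toxicity in this test: compound 1 gives 63000 nM. Compound 2 `O=C1c2ccccc2N(Cc2ccccc2-c2ccccc2)S(=O)(=O)N1Cc1ccccc1` is recorded only as a limit of the assay, > 55000 nM. Compound 3 `O=C1c2ccccc2N(Cc2ccc(Cl)cc2)S(=O)(=O)N1Cc1ccccc1` differs from compound 1 by chloro in place of methyl on an aromatic carbon. For the measured compounds named here, no measured step between two compounds is available here, so compound 3 is expected to stay close to compound 1, and the step of a 1.3-fold lower number from compound 1 to compound 3 (0.10 log units; within the scatter) is expected to remain within the usual scatter. The estimate for compound 3 is 50000 nM, within 20000 nM to 130000 nM.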

Compound 3, half-maximal cytotoxic concentration: 60000 nM
Estimate against measurement, compound 3: 1.2-fold (0.08 log units) below, and the stated range covers the measured number.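

Chloro in place of methyl at this position, on the aromatic carbon para to a large group, gives the only readable step in this assay: a 1.1-fold lower number from compound 1 to compound 3 (0.02 log units; within the scatter). So 4-chlorobenzyl and 4-methylbenzyl cannot be told apart on this read-out. Compound 2 offers no comparison, since it is recorded only as a limit of the assay: the limit of > 55000 nM in this assay, at which 1 of the 3 values shown sits.

From the compounds shown here alone, whether an amine, a carboxylic acid or a longer chain at this position would shift the number stays open. So does whether chloro would behave the same way on the other benzyl group.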